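Ring hydroxyl epimer: permeability notes on a bicyclic amide

The compounds below may be only part of what the source reports. "The series", "measured", "known", "first", "only" and "open" are said of these compounds alone.

Compound 1 `CC[C@@H](c1ccccc1)n1nc(C(=O)NC)cc1C(=O)N[C@H]1[C@@H]2C[C@H](O)C[C@@H]21` holds the higher of the two numbers obtained so far in an ADME assay for permeability; a higher number here means that the compound crosses the layer faster, a lower number that the compound crosses the layer more slowly: compound 1 gives 230 nm/s. Compound 2 `CNC(=O)c1cc(C(=O)N[C@H]2CC[C@H](O)CC2)c([C@@H](C)c2cccc(OC)c2)o1` stands well apart; in this assay compound 2 gives 44 nm/s, a value beyond the scatter below that of compound 1. The two compounds differ in many places at once, so nothing more than the two numbers themselves is taken from that gap.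

Compound 3 `CC[C@@H](c1ccccc1)n1nc(C(=O)NC)cc1C(=O)N[C@H]1[C@@H]2C[C@@H](O)C[C@@H]21` has not yet been measured. Relative to compound 1 the change is the two compounds have the same atoms and bonds and differ only in configuration as drawn: 1 of 5 stereo elements differ; a stereocentre at a saturated ring carbon is drawn S in compound 1 and R in compound 3. Within the data shown here, no pair of measured compounds differs in exactly this way, so no measured step of this type exists. Among the measured compounds shown here, nothing among the measured compounds points to a direction for this change, and the drawn configuration at one saturated ring carbon is the only difference. Compound 3 is therefore expected to give 200 nm/s in this assay, with an expected range of 100 nm/s to 400 nm/s. The expected step of a 1.2-fold lower number from compound 1 to compound 3 (0.06 log units; within the scatter) is estimated to lie within the usual scatter, in no preferred direction.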

Compound 3, apparent permeability: 120 nm/s
Estimate against measurement, compound 3: 1.7-fold (0.22 log units) above, within the range that was stated.
By their numbers in this assay, from the lowest: compound 2; then compounds 3 and 1 (each within the scatter of the next).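

The series now holds a measured step for the stereocentre at this saturated ring carbon, and this pair can be read directly, with no second difference to separate from the drawn configuration: the fact that compounds 1 and 3 differ only in the configuration as drawn. In this assay the step is a 1.9-fold lower number from compound 1 to compound 3 (0.28 log units; within the scatter), so the S and R forms at this carbon cannot be told apart on this pair. That reading rests on a single pair and applies only to this ring carbon on this core, not to the other stereo elements of compound 1.

Still open, from the compounds shown here alone, is whether the configuration at this carbon would matter as little with another group in place of the hydroxyl, such as an amine or a carboxylic acid, since all the compounds with this core carry the hydroxyl. Going by these compounds, a longer chain in place of the ethyl group of compound 1 is also open, as is the question of whether the S and R forms would stay within the scatter of each other on such an analogue.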